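From 2-methoxyphenyl to 4-cyanophenyl on a shared core

The source may report more compounds than this note shows. Statements on the series, on what has been measured and on what is new or still open speak of the compounds shown alone.

Compound 1 `COc1ccccc1-n1cc(CN2C(=O)C[C@@H]3CC[C@@]2(C)C3(C)C)nn1` gives 350 nM in a functional assay on A549 cells (Homo sapiens) for inhibition, read by MTT assay, with a stated time of 24 h (a higher number here means a weaker inhibitor, a lower number a stronger inhibitor), the highest number among the three compounds measured. Compound 2 `CC1(C)[C@H]2CC[C@]1(C)N(Cc1cn(-c3ccccc3Br)nn1)C(=O)C2` gives 130 nM and compound 3 `CC1(C)[C@H]2CC[C@]1(C)N(Cc1cn(-c3ccccc3Cl)nn1)C(=O)C2` gives 70 nM, so compound 1 sits nearest to compound 2 and furthest from compound 3. The two measured steps that start from compound 1 both exchange the methoxy group for a halogen: a 2.7-fold lower number from compound 1 to compound 2 (0.43 log units; beyond the scatter), and a 5.0-fold lower number from compound 1 to compound 3 (0.70 log units; beyond the scatter). Between the two halogens, a 1.9-fold lower number from compound 2 to compound 3 (0.27 log units; within the scatter).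

Compound 4 `CC1(C)[C@H]2CC[C@]1(C)N(Cc1cn(-c3ccc(C#N)cc3)nn1)C(=O)C2` has not been measured. It differs from compound 1 as follows: 4-cyanophenyl in place of 2-methoxyphenyl on an aromatic nitrogen. This change goes further than the halogen steps, since the whole 2-methoxyphenyl is replaced by 4-cyanophenyl, a group carrying a nitrile, and no nitrile has been tested in this assay among these compounds. Going by the values given here, both steps away from the methoxyphenyl lowered the number modestly, and no measured compound speaks against that. Because a 2.7-fold lower number from compound 1 to compound 2 (0.43 log units; beyond the scatter) and a 5.0-fold lower number from compound 1 to compound 3 (0.70 log units; beyond the scatter) both point the same way, a modestly lower number is expected for compound 4, with a wide range. Compound 4 is therefore expected to give 180 nM, between 60 nM and 550 nM, which corresponds to an expected step of a 1.9-fold lower number from compound 1 to compound 4 (0.29 log units; within the scatter).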

Compound 4, half-maximal inhibitory concentration: 140 nM
For compound 4 the middle estimate is 1.3-fold (0.11 log units) above the measured one, and the stated range covers the measured number.
By their numbers in this assay, from the lowest: compounds 3, 2 and 4 (each within the scatter of the next); then compound 1.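

The step away from the 2-methoxyphenyl in this assay does not depend on a halogen, as the 4-cyanophenyl also gives a lower number (a 2.5-fold lower number from compound 1 to compound 4 (0.40 log units; beyond the scatter)), so all three replacements on this aromatic nitrogen now read the same way relative to compound 1, and none goes against this. The nitrile compound cannot be told apart from either halogen compound, with a 2.0-fold higher number from compound 3 to compound 4 (0.30 log units; within the scatter) and a 1.1-fold higher number from compound 2 to compound 4 (0.03 log units; within the scatter), which means that 2-chlorophenyl, 2-bromophenyl and 4-cyanophenyl are not separated by this measurement, even though the first two carry a halogen and the third a triple bond. Nothing measured here gives a reason for the result.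

The compounds shown leave open whether the step to compound 4 follows from the nitrile itself or from where it sits on the phenyl ring, as the group and its place change together in this comparison. They also leave open how a plain phenyl, or a phenyl carrying an amine or a carboxylic acid, would read on the shared core in this assay.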